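Replacing Vinyl on a Sulfur-Bound Chain Carbon

The source may hold more compounds than are shown below. What is called first, only, known or untested is meant among the compounds shown, and "the series" means these compounds.

Measured in a functional assay on HT cells (Homo sapiens) for antiproliferative activity, read by fluorescence, with a stated time of 72 h; on this read-out higher numbers stand for weaker inhibition of growth and lower numbers for stronger inhibition of growth:
- compound 1 `CC(C)c1n[nH]c2c(NCc3ccc(-c4ccccn4)cc3)nc(SCC(O)CO)nc12` gives 21 nM
- compound 2 `C=CCSc1nc(NCc2ccc(-c3ccccn3)cc2)c2[nH]nc(C(C)C)c2n1` gives 1010 nM

Of these two numbers, compound 2 has the higher one, 1010 nM, which means weaker inhibition of growth than compound 1 shows. Compound 3 (`CC(=O)NCCSc1nc(NCc2ccc(-c3ccccn3)cc2)c2[nH]nc(C(C)C)c2n1`) has not yet been measured and differs from compound 2 at one place: acetamidomethyl in place of vinyl on a saturated chain carbon bound to a sulfur. Here, acetamidomethyl stands in place of vinyl on a saturated chain carbon bound to a sulfur.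

Among the measured compounds shown here, only one measured step bears on this place: a 48-fold higher number from compound 1 to compound 2 (1.68 log units; beyond the scatter). In that large step, vinyl stands in place of 1,2-dihydroxyethyl, so the group here can shift the number strongly. For the measured compounds named here, compound 1 shows that a group other than vinyl can give a far lower number, but no measurement yet covers acetamidomethyl. A clear move toward stronger inhibition in this assay is therefore expected, probably only part of the way to compound 1. The expected change is a 6.7-fold lower number from compound 2 to compound 3 (0.83 log units; beyond the scatter), and it remains uncertain because it rests on a single step. Compound 3 is estimated at 150 nM (expected range 35 nM to 600 nM).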

Compound 3, concentration for 50% growth inhibition: 71 nM
Beside the measured number, compound 3's estimate is 2.1-fold (0.32 log units) above it, within the range that was stated.
By their numbers in this assay, from the lowest: compound 1; then compound 3; then compound 2.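

In this assay, the low number of compound 1 turns out not to be unique to 1,2-dihydroxyethyl: swapping vinyl for acetamidomethyl on the saturated chain carbon bound to a sulfur gives a 14-fold lower number from compound 2 to compound 3 (1.15 log units; beyond the scatter), so a second, quite different group also leaves vinyl far behind. The two better groups are still not equal, since replacing 1,2-dihydroxyethyl with acetamidomethyl gives a 3.4-fold higher number from compound 1 to compound 3 (0.53 log units; beyond the scatter), a modest step, but one that lies beyond the usual scatter. Nothing given here explains these differences.

Acetamidomethyl brings a hydrogen-bond donor and a hydrogen-bond acceptor where vinyl has neither, but the compounds shown cannot tell whether this matters or whether the larger size of the group does, since the two changes arrive together. From the compounds shown here alone, it also remains open how a simple amine or a carboxylic acid would behave on this chain carbon, and whether a longer chain ending in the same amide would keep, lose or improve on the number of compound 3.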